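Swapping chloro for bromo in a clearance series

The source may hold more compounds than are shown below. What is called first, only, known or untested is meant among the compounds shown, and "the series" means these compounds.

Measured so far:
- compound 1 `CCOC(=O)c1c(-c2cccc(Oc3ccccc3)c2)[nH]c2cc(OC)c(F)cc2c1=O`: 16 mL.min-1.g-1
- compound 2 `CCOC(=O)c1c(-c2cccc(Cl)c2)[nH]c2cc(OC)c(F)cc2c1=O`: 4 mL.min-1.g-1

Both values come from an in vitro ADME assay on microsomes from liver (Mus musculus, strain CD1) for metabolic stability, read by HPLC, with a stated time of 4 h; on this read-out higher numbers stand for fast clearance and lower numbers for slow clearance. For the measured compounds named here, of the two numbers, compound 2 holds the lower one, 4 mL.min-1.g-1, and its only neighbour is compound 1 at 16 mL.min-1.g-1.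

The next compound to be measured is compound 3 `CCOC(=O)c1c(-c2cccc(Br)c2)[nH]c2cc(OC)c(F)cc2c1=O`, which differs from compound 2 in one place: bromo in place of chloro on an aromatic carbon. In words, this is bromo in place of chloro on an aromatic carbon, meta to a large group.

Going by the values given here, no measured compound carries bromo, so the data hold no direct precedent. Among the compounds with values here, the only measured step, a 4.0-fold lower number from compound 1 to compound 2 (0.60 log units; beyond the scatter), lies beyond the scatter, but it removed phenoxy and is therefore a weak guide to a swap that removes only chloro. No step beyond the scatter is expected here, and the direction is uncertain. The estimate amounts to a 1.3-fold higher number from compound 2 to compound 3 (0.10 log units; within the scatter), an expected change within the usual noise.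

In this assay, compound 3 is expected to give 5 mL.min-1.g-1, with an estimated range from 2.5 mL.min-1.g-1 to 10 mL.min-1.g-1.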

Compound 3, intrinsic clearance in microsomes: 2.7 mL.min-1.g-1
Compound 3: the middle estimate sits 1.9-fold (0.27 log units) above what was measured; low and high end bracket the measured number.
By their numbers in this assay, from the lowest: compounds 3 and 2 (each within the scatter of the next); then compound 1.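

In this assay, bromo in place of chloro gives a 1.5-fold lower number from compound 2 to compound 3 (0.17 log units; within the scatter) and stays within the scatter, so this pair shows that the two groups cannot be told apart on this read-out at this spot on the aromatic ring. Bromo in place of phenoxy gives a 5.9-fold lower number from compound 1 to compound 3 (0.77 log units; beyond the scatter) and lies beyond the scatter, in the same direction as a 4.0-fold lower number from compound 1 to compound 2 (0.60 log units; beyond the scatter) for chloro, so the drop from compound 1 now appears with two different replacements rather than one. No measurement shown here explains these numbers.

The three compounds shown carry only phenoxy, chloro or bromo at this spot, so it remains open whether a nitrile, an amine or a carboxylic acid there would give a number as low as those of compound 2 and compound 3. All three also share the same core and the same ethyl ester, which leaves open whether this pattern would hold with a different ester or with a carboxylic acid in its place.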